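The source may report more compounds than this note shows. Statements on the series, on what has been measured and on what is new or still open speak of the compounds shown alone.

Measured so far, with structures and values:
compound 1 `C/C(=C\c1ccc(-c2ccc(F)cc2)o1)C(N)=O` gives 1650 nM
compound 2 `C/C(=C\c1cc(-c2ccc(C)cc2)cs1)C(N)=O` gives only a limit, > 50000 nM
compound 3 `C/C(=C\c1cccc(-c2ccccc2)c1)C(N)=O` gives only a limit, > 50000 nM

All three carry the same propenamide chain on a different aromatic core. In a functional assay on A549 cells (Homo sapiens) for cytotoxicity, read by CCK-8 assay, with a stated time of 24 h (on this read-out lower numbers stand for stronger inhibition and higher numbers for weaker inhibition), compound 1 gives a numeric value, 1650 nM. Compound 3 instead sits at the limit of the assay, > 50000 nM, which is where most of the shown values lie (the limit of > 50000 nM in this assay, at which 2 of the 3 values shown sit). Compound 4 `C/C(=C\c1cccc(-c2ccc(C)cc2)c1)C(N)=O` is not yet measured; it differs from compound 3 by methyl in place of hydrogen on an aromatic carbon. Among the measured compounds shown here, no measured pair shows this change, so no step beyond the scatter is expected, and compound 4 may again come back only as a limit. The expected step is a step that the limit leaves unreadable from compound 3 to compound 4. Compound 4 is estimated at 60000 nM, with a range from 15000 nM to 200000 nM.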

Compound 4, half-maximal inhibitory concentration: 5100 nM
Beside the measured number, compound 4's estimate is 12-fold (1.07 log units) above it, and the stated range ends above it.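

On this assay methyl in place of hydrogen on an aromatic carbon, para to a large group, gives an at least 9.8-fold lower number from compound 3 to compound 4 (0.99 log units; beyond the scatter) and so shows that this position can respond to a small change. A single added carbon is enough to turn a limit into a readable number. The true size of the step stays unknown, because one end of it is a limit rather than a number: the limit of > 50000 nM in this assay, at which 2 of the 4 values shown sit.

As far as these compounds go, whether an ethyl, a methoxy or a chlorine at this position would lower the number further remains open.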